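A few compounds are considered here, and "the series" means these few. Any claim that something is new, unique, unknown or untested is made for them only; others in the source may bear on it.

Measured compounds:
compound 1, `COc1cc(Cl)cc(-c2nn(-c3cccc(NC(=O)Nc4cccc(C(F)(F)F)c4)c3)cc2-c2ccncc2)c1`, 13.2%;
compound 2, `COc1cc(Cl)cc(-c2nn(-c3cccc(NC(=O)c4cc(C(F)(F)F)cc(C(F)(F)F)c4)c3)cc2-c2ccncc2)c1`, 80.2%;
compound 3, `COc1cc(Cl)cc(-c2nn(-c3cccc(NC(=O)c4ccc(Cl)c(Cl)c4)c3)cc2-c2ccncc2)c1`, 74.1%.

All three were tested in a functional assay on 786-0 cells (Homo sapiens) for inhibition, read by sulforhodamine B assay, with a stated time of 48 h, tested at 10 uM; a higher number here means a weaker effect of the compound at the concentration tested, a lower number a stronger effect. On these numbers compound 3 stands second highest of the three: its nearest neighbour is compound 2, whose number is higher but within the scatter, while compound 1 lies far below it, beyond the scatter. Among the measured compounds shown here, the only step that changes one place, a number 60.9 percentage points higher from compound 1 to compound 3 (beyond the scatter), replaces a urea-type group with an amide-type one and is large; it does not directly bear on the next change.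

Compound 4, `COc1cc(Cl)cc(-c2nn(-c3cccc(NC(=O)c4cccc(C(F)(F)F)c4)c3)cc2-c2ccncc2)c1`, has not yet been measured in this assay. It differs from compound 3 in one place: 3-(trifluoromethyl)phenyl in place of 3,4-dichlorophenyl on a carbonyl carbon. For the measured compounds named here, no measured step covers this exact exchange. What the data do show is that compound 2, which also carries an amide-type group on the same carbonyl carbon and bears trifluoromethyl groups, gives a number close to compound 3. From this, compound 4 is expected to stay near compound 3, with a number 1.9 percentage points higher from compound 3 to compound 4 (within the scatter) expected to lie within the scatter. Compound 4 is therefore estimated at 76%, in the range from 58% to 92%.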

Compound 4, a percentage reported as activity, at one concentration (the size of the read-out at that concentration, not a potency): 66.6%
Beside the measured number, compound 4's estimate is 9.4 percentage points above it, within the range that was stated.
By their numbers in this assay, from the lowest: compound 1; then compounds 4, 3 and 2 (each within the scatter of the next, the first and the last beyond it).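

In this assay, exchanging 3,4-dichlorophenyl for 3-(trifluoromethyl)phenyl on the carbonyl carbon leaves the reading within the scatter, with a number 7.5 percentage points lower from compound 3 to compound 4 (within the scatter), so these two rings cannot be told apart here. Taking one trifluoromethyl off the ring of compound 2 has a modest but real effect, with a number 13.6 percentage points lower from compound 2 to compound 4 (beyond the scatter), which points to a somewhat stronger effect for the ring with a single trifluoromethyl group. The largest contrast comes from keeping the same 3-(trifluoromethyl)phenyl ring and changing only the link: with a number 53.4 percentage points higher from compound 1 to compound 4 (beyond the scatter), the urea-type compound 1 has a far stronger effect than the amide-type compound 4, and this comparison isolates the link without the ring change that accompanied the earlier step from compound 1 to compound 3.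

Still open, from the compounds shown here alone, is how an amine or a carboxylic acid in place of trifluoromethyl on this ring would read, and whether (3,4-dichlorophenyl)amino on the carbonyl carbon would match the strong effect of compound 1. Nothing measured here gives a reason for the size of any of these steps.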